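Position of the hydroxy group and tolerated concentration

This account rests on a few compounds, and the source may have more. Where it says the series, first, only, none or still open, it means among the compounds named here.

Compound 3 `O=C(CSc1nnnn1-c1cccc2ccccc12)N/N=C/c1cccc(O)c1` gives the highest number of the three measured compounds in an ADME assay on MT4 cells (Homo sapiens) for cytotoxicity, read by MTT assay (a lower number here means that less compound is tolerated, a higher number that more compound is tolerated), at 169000 nM. Compound 1 `O=C(CSc1nnnn1-c1cccc2ccccc12)N/N=C/c1ccccc1Cl` gives 69700 nM in this assay, and compound 2 `O=C(CSc1nnnn1-c1cccc2ccccc12)N/N=C/c1ccccc1O` gives 4850 nM; the steps of a 2.4-fold higher number from compound 1 to compound 3 (0.38 log units; beyond the scatter) and a 35-fold higher number from compound 2 to compound 3 (1.54 log units; beyond the scatter) both lie beyond the scatter, while a 14-fold lower number from compound 1 to compound 2 (1.16 log units; beyond the scatter) runs the other way.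

Compound 4 `O=C(CSc1nnnn1-c1cccc2ccccc12)N/N=C/c1ccc(O)cc1` differs from compound 3 only in where the hydroxy group sits: 4-hydroxyphenyl in place of 3-hydroxyphenyl on a carbon with a double bond to nitrogen. Within the data shown here, the one measured step that moves the hydroxy group around the ring, a 35-fold higher number from compound 2 to compound 3 (1.54 log units; beyond the scatter), was large, so a shift of this kind can change the number considerably. Among the measured compounds shown here, no measured pair, however, compares the 3-hydroxyphenyl with the 4-hydroxyphenyl, and the 2-hydroxyphenyl of compound 2 is the one that stands apart. A step close to the scatter, a 1.4-fold lower number from compound 3 to compound 4 (0.15 log units; within the scatter), is therefore expected, with a modest fall more likely than a rise. Compound 4 is estimated at 120000 nM, within 40000 nM to 300000 nM.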

Compound 4, half-maximal cytotoxic concentration: > 309000 nM
Compound 4: a limit, no number; the forecaster's own chance of this, stated with the estimate: 25%; middle value at least 2.5-fold (0.41 log units) away from the limit.
By their numbers in this assay, from the lowest: compound 2; then compound 1; then compound 3. At a limit, above all of these: compound 4.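

In this assay compound 4 gives > 309000 nM, which is a limit of the assay and not a number. The change to 4-hydroxyphenyl on a carbon with a double bond to nitrogen gives an at least 1.8-fold higher number from compound 3 to compound 4 (0.26 log units; that floor lies within the scatter), so the floor does not separate these two compounds beyond the scatter, whereas an at least 63-fold higher number from compound 2 to compound 4 (1.80 log units; beyond the scatter) and an at least 4.4-fold higher number from compound 1 to compound 4 (0.64 log units; beyond the scatter) both clear it. Among the three hydroxyphenyl compounds, compound 2 with its 2-hydroxyphenyl now stands alone at the low end, while compound 3 and compound 4 both give far higher readings.

From the compounds shown here alone, with compound 4 at a limit, the full size of its steps remains unknown. Also open, going by these compounds, is whether a methoxy group or an amine in place of the hydroxy group of the 2-hydroxyphenyl would keep the low number of compound 2.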